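A few compounds are considered here, and "the series" means these few. Any claim that something is new, unique, unknown or untested is made for them only; others in the source may bear on it.

Working notes on the amide series. In a functional assay on HCT-116 cells (Homo sapiens) for antiproliferative activity, read by MTT assay, with a stated time of 48 h (a higher number here means a weaker inhibitor, a lower number a stronger inhibitor), compound 3 `Cc1ccc(NC(=O)c2oc3ccc(N(Cc4ccc(Br)cc4)S(=O)(=O)c4ccc(Br)cc4)cc3c2C)nc1` gives > 40000 nM, which is a limit and not a number. Compound 1 `Cc1c(C(=O)NCCS(C)(=O)=O)oc2ccc(N(Cc3ccc(Br)cc3)S(=O)(=O)c3ccc(Br)cc3)cc12` gives > 40000 nM, also a limit. Within the data shown here, compound 2 `Cc1c(C(=O)N2CCCC(C)C2)oc2ccc(N(Cc3ccc(Br)cc3)S(=O)(=O)c3ccc(Br)cc3)cc12` gives 28300 nM, the only actual number so far. The series therefore stands close to the limit of > 40000 nM in this assay, at which 2 of the 3 values shown sit, and compound 3 offers no exact starting point.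

Compound 4 `Cc1c(C(=O)NCCNc2ccccc2)oc2ccc(N(Cc3ccc(Br)cc3)S(=O)(=O)c3ccc(Br)cc3)cc12` carries 2-anilinoethyl in place of 5-methylpyridin-2-yl on an amide-type nitrogen. The same place is varied in the measured steps. These are an at least 1.4-fold lower number from compound 1 to compound 2 (0.15 log units; that floor lies within the scatter) and an at least 1.4-fold higher number from compound 2 to compound 3 (0.15 log units; that floor lies within the scatter), and both are only floors within the scatter. The third is a step that the two limits leave unreadable from compound 1 to compound 3. None of the three shows a change beyond the scatter, so they give no direction for the new group.

In this assay no step beyond the scatter is therefore expected, and a further limit reading is about as likely as a number. The expected step is an at least 1.2-fold lower number from compound 3 to compound 4 (0.09 log units; that floor lies within the scatter). The estimate for compound 4 is 32000 nM, with an expected range from 12000 nM to 60000 nM.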

Compound 4, half-maximal inhibitory concentration: > 40000 nM
Compound 4: a limit, no number; the forecaster's own chance of this, stated with the estimate: 50%; at least 1.2-fold (0.09 log units) between middle value and limit.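

In this assay compound 4 gives > 40000 nM, which is a limit and not a number. With this result, a chain ending in an aromatic ring of carbon only, 2-anilinoethyl, joins 5-methylpyridin-2-yl and 2-(methylsulfonyl)ethyl among the groups on the amide-type nitrogen that give no number. The one step that can be read is an at least 1.4-fold higher number from compound 2 to compound 4 (0.15 log units; that floor lies within the scatter), the steps to compound 4 from compound 1 and from compound 3 cannot be read, and the position now reads almost flat: the limit of > 40000 nM in this assay, at which 3 of the 4 values shown sit.

Compound 2, with 3-methylpiperidin-1-yl on the carbonyl carbon, remains the only compound with a number, and no step shown lies beyond the scatter, so it remains open whether this place can move the value at all. Also open, as far as these compounds go, is whether a plain piperidine or a morpholine on the carbonyl carbon, or a carboxylic acid at the end of the chain on the amide-type nitrogen, would give a number clearly apart from that of compound 2.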